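Swapping methyl for phenyl on a thiophene-bearing compound

The source may hold more compounds than are shown below. What is called first, only, known or untested is meant among the compounds shown, and "the series" means these compounds.

Compound 1 (`CN1C/C(=C\c2cccs2)C(O)/C(=C/c2cccs2)C1`) 96200 nM
Compound 2 (`CN1C/C(=C\c2cccs2)C2=NN(C)C(c3cccs3)C2C1`) 89700 nM

In a functional assay on cells (Panel renal (Carcinoma cell lines), Homo sapiens) for inhibition (a lower number here means a stronger inhibitor of growth, a higher number a weaker inhibitor of growth), compound 1 gives 96200 nM and compound 2 gives 89700 nM (these two values lie within the usual scatter of each other). On these numbers the two compounds cannot be told apart, even though their structures differ in more than one place.

Compound 3 (`CN1C/C(=C\c2cccs2)C2=NN(c3ccccc3)C(c3cccs3)C2C1`) has not yet been measured. It is compound 2 with one change: phenyl in place of methyl on an amine nitrogen in a ring. Among the measured compounds shown here, no two measured compounds differ in one place only, so the data offer no direct guide to what this swap does, and any forecast is uncertain. With compound 2 at 89700 nM in this assay, a modest move toward stronger growth inhibition seems more likely than a large one. The step expected is a 2.2-fold lower number from compound 2 to compound 3 (0.35 log units; beyond the scatter) and it points toward a lower number. Compound 3 is estimated at 40000 nM (expected range 12000 nM to 100000 nM) in this measurement.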

Compound 3, concentration for 50% growth inhibition: 65300 nM
Beside the measured number, compound 3's estimate is 1.6-fold (0.21 log units) below it; the range from low to high includes it.
By their numbers in this assay, from the lowest: compounds 3, 2 and 1 (each within the scatter of the next).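

In this assay, putting phenyl in place of methyl on this amine nitrogen gives a 1.4-fold lower number from compound 2 to compound 3 (0.14 log units; within the scatter). Among the compounds shown here, this is the first pair that differs in one place only, so it gives the first direct reading of this position: a ring of six carbons can stand where a single carbon stood, and the two compounds still cannot be told apart in this measurement. No other measurement here bears on this result.

From the compounds shown here alone, a single swap at one nitrogen says little about the position as a whole, so it remains open whether a hydrogen, a benzyl group or a phenyl carrying a carboxylic acid or an amine on this nitrogen would move the number beyond the scatter. Also open, going by these compounds, is what would happen if the thiophen-2-yl group on the ring atom next to this nitrogen gave way to a phenyl or a longer chain, since that group stays the same in compound 2 and compound 3.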